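Ring closure of the chain amine: compound 3 to compound 4

A few compounds are considered here, and "the series" means these few. Any claim that something is new, unique, unknown or untested is made for them only; others in the source may bear on it.

Measured so far:
compound 1 `CCCCNc1nc(N)nc(C)c1C` gives 3280 nM in an assay on HEK293 cells for agonist activity at Toll-like receptor 8 (Homo sapiens), read by spectrophotometry; on this read-out lower numbers stand for an effect already at smaller amounts and higher numbers for an effect only at larger amounts of compound
compound 2 `CCCCCc1c(C)nc(N)nc1NCCCC` gives 1220 nM in this assay
compound 3 `CCCCNc1nc(N)nc(C)c1CCCN(CC)CC` gives 254 nM in this assay

Compound 3 holds the lowest number of the three in this assay: a 4.8-fold lower number from compound 2 to compound 3 (0.68 log units; beyond the scatter) and a 13-fold lower number from compound 1 to compound 3 (1.11 log units; beyond the scatter), both beyond the scatter. Compound 4 `CCCCNc1nc(N)nc(C)c1CCCN1CCCCC1` keeps the shared core and the chain on it; the difference is piperidin-1-yl in place of diethylamino on a saturated chain carbon, three bonds along the chain from an aromatic carbon.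

The step that bears most closely is a 4.8-fold lower number from compound 2 to compound 3 (0.68 log units; beyond the scatter), which put the amine at this very place and was modest. The chain alone gave a 2.7-fold lower number from compound 1 to compound 2 (0.43 log units; beyond the scatter). Within the data shown here, no measured pair sets an open-chain amine against a ring-closed one at this place, so the size of the ring closure is not anchored by the data. The nitrogen and its attachment to the chain are retained; two chain carbons are tied into a ring. The step is expected to be small, within the scatter: a 1.2-fold lower number from compound 3 to compound 4 (0.06 log units; within the scatter). Compound 4 is estimated at 220 nM in this assay, with a range of 80 nM to 600 nM.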

Compound 4, half-maximal effective concentration: 133 nM
Beside the measured number, compound 4's estimate is 1.7-fold (0.22 log units) above it; low and high end bracket the measured number.
By their numbers in this assay, from the lowest: compounds 4 and 3 (each within the scatter of the next); then compound 2; then compound 1.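

Ring closure at this place is now read directly for the first time: in this assay the change from diethylamino to piperidin-1-yl gives a 1.9-fold lower number from compound 3 to compound 4 (0.28 log units; within the scatter) and so leaves the number within the scatter of the open-chain amine. The ring-closed amine also keeps the gain over the ethyl end of compound 2, with a 9.2-fold lower number from compound 2 to compound 4 (0.96 log units; beyond the scatter) beyond the scatter, so among these compounds both compound 3 and compound 4, each with a chain amine, hold lower numbers than compound 2, and none goes against this. No supporting measurement is available to explain either step.

From the compounds shown here alone, whether a smaller ring such as pyrrolidin-1-yl or a ring with a second hetero atom such as morpholin-4-yl would fit this place stays open. So does the effect of a longer chain carrying the piperidin-1-yl group.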